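The compounds below may be only part of what the source reports. "The series", "measured", "known", "first", "only" and "open" are said of these compounds alone.

Of the compounds shown here, three have so far been measured in a functional assay on HEK293 cells for antagonist activity at Voltage-dependent T-type calcium channel subunit alpha-1G (Homo sapiens), read by patch clamp (a lower number here means a stronger inhibitor, a higher number a weaker inhibitor), all built on a shared chain in which an ester-bearing quaternary carbon is linked through a methylated amine to a benzimidazole. Compound 1 `CCOC(=O)C(CCCN(C)CCCc1nc2ccccc2[nH]1)(c1ccccc1)C(C)C` gives 250 nM. Compound 2 `CCOC(=O)C(CCCN(C)CCCc1nc2cc(C)c(C)cc2[nH]1)(c1ccccc1)C(C)C` gives 100 nM, so that the change 5,6-dimethyl-1H-benzimidazol-2-yl in place of 1H-benzimidazol-2-yl on a saturated chain carbon, three bonds along the chain from an amine nitrogen produced a step of a 2.5-fold lower number from compound 1 to compound 2 (0.40 log units; beyond the scatter). Compound 3 `COC(=O)C(CCCN(C)CCCc1nc2ccccc2[nH]1)(c1ccc(Br)cc1)C(C)C` gives 8.17 nM, the lowest of the three numbers; how its core differs from that of compound 1 is not broken down here. Compound 4 `COC(=O)C(CCCN(C)CCCc1nc2cc(C)c(C)cc2[nH]1)(c1ccc(Br)cc1)C(C)C` has not yet been measured in this assay. Among the measured compounds shown here, it differs from compound 3 by 5,6-dimethyl-1H-benzimidazol-2-yl in place of 1H-benzimidazol-2-yl on a saturated chain carbon, three bonds along the chain from an amine nitrogen, which is the same change, at the same place, as the one separating compound 1 from compound 2. For the measured compounds named here, compound 4 is therefore expected to show a step of a 2.0-fold lower number from compound 3 to compound 4 (0.31 log units; beyond the scatter), because a 2.5-fold lower number from compound 1 to compound 2 (0.40 log units; beyond the scatter) arose from that same single change, which is the only difference from compound 3. Compound 4 is estimated at 4 nM, between 1.5 nM and 12 nM.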

Compound 4, half-maximal inhibitory concentration: 53 nM
Estimate against measurement, compound 4: 13-fold (1.12 log units) below; the whole stated range lies below it.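

On the core of compound 3, the change to 5,6-dimethyl-1H-benzimidazol-2-yl gives a 6.5-fold higher number from compound 3 to compound 4 (0.81 log units; beyond the scatter), a step in the opposite direction to the one seen on the core of compound 1. In this assay, the result of this change therefore depends on the core that carries it, and the step from one core cannot be transferred to the other: the same change on two cores in this assay, a 2.5-fold lower number (0.40 log units; beyond the scatter) from compound 1 to compound 2 and a 6.5-fold higher number (0.81 log units; beyond the scatter) from compound 3 to compound 4, 16-fold (1.21 log units) apart, beyond the scatter of two such steps

Among the compounds shown here, with only two pairs, this does not show which difference between the two cores is responsible, nor how the change would behave on any further core. The compounds shown leave open whether a carboxylic acid or an amide in place of the ester would alter the step, and whether the outcome would hold with a longer chain. They also leave open how a single methyl group or a chlorine on the 1H-benzimidazol-2-yl group would compare with the 5,6-dimethyl group on each core.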